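The source may hold more compounds than are shown below. What is called first, only, known or untested is meant among the compounds shown, and "the series" means these compounds.

Measured compounds:
compound 1, `O=C1c2ccccc2N(Cc2ccccc2)S(=O)(=O)N1COCc1ccccc1`: 100000 nM
compound 2, `O=C1c2ccccc2N(Cc2cccc(Cl)c2)S(=O)(=O)N1Cc1ccccc1`: 2100000 nM
compound 3, `O=C(OCOCN1c2ccccc2C(=O)N(Cc2ccccc2)S1(=O)=O)c1ccccc1`: 100000 nM

In a functional assay on CCRF-CEM cells (Homo sapiens) for inhibition (a lower number here means that less compound is tolerated, a higher number that more compound is tolerated), compound 3 stands level with compound 1 at the digits given, and these two together hold the lowest numbers of the three. Compound 2 lies beyond the scatter from both of them, with a higher number, so the shared core tolerates the substituent pattern of compound 2 best.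

Compound 4, `O=C1c2ccccc2N(COCc2ccccc2)S(=O)(=O)N1Cc1ccccc1`, has not yet been measured in this assay. It differs from compound 3 in one place: phenyl in place of benzoyloxy on a saturated chain carbon bound to an oxygen on a saturated carbon. The change shortens the side chain on a saturated chain carbon bound to an oxygen on a saturated carbon, and the groups that remain on compound 4 are the same two that compound 1 carries, which in this assay gives 100000 nM. Among the compounds with values here, none of the measured pairs shows what the loss of a benzoyloxy group does on the shared core, so no direction can be read from the data. The step from compound 3 to compound 4 is therefore expected to stay within the scatter, as a 1.2-fold higher number from compound 3 to compound 4 (0.08 log units; within the scatter), with either direction possible. For compound 4 the estimate in this assay is 120000 nM, with a range from 35000 nM to 400000 nM.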

Compound 4, half-maximal cytotoxic concentration: 25000 nM
Beside the measured number, compound 4's estimate is 4.8-fold (0.68 log units) above it; measured number outside the range, below it.
By their numbers in this assay, from the lowest: compound 4; then compounds 1 and 3 (each within the scatter of the next); then compound 2.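

In this assay the change of phenyl in place of benzoyloxy on a saturated chain carbon bound to an oxygen on a saturated carbon, read one bond further out as (benzoyloxy)methyl to benzyl, gives a 4.0-fold lower number from compound 3 to compound 4 (0.60 log units; beyond the scatter) and so shows that the group at this position can move the number beyond the scatter, towards less compound tolerated. In the same assay, benzyloxy in place of 3-chlorophenyl on a saturated chain carbon bound to a sulfonamide nitrogen in a ring gives an 84-fold lower number from compound 2 to compound 4 (1.92 log units; beyond the scatter) as a larger step that runs in the same direction, which makes this second position the one with the greater reach among the steps read so far. Nothing available bears on the reason for either step.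

Each of these changes rests on a single pair, so neither size nor direction can yet be taken as a trend on the shared core. Open, going by these compounds, is how an amine, a carboxylic acid or a longer chain in place of phenyl on the saturated chain carbon bound to an oxygen would compare, and whether 3-chlorophenyl at that place would raise the number.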